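The compounds below may be only part of what the source reports. "The series", "measured", "known", "first", "only" and "open" are said of these compounds alone.

Series notes. Compound 1 `N/C(=N\NC(=S)N1CCSCC1)c1ccccn1` and compound 2 `N/C(=N\NC(=S)N1CCOCC1)c1ccc(F)cn1` have been run in a functional assay on A-375 cells (Homo sapiens) for cytotoxicity, read by MTT assay, with a stated time of 72 h, tested at 30 uM; a lower number here means less inhibition of growth, a higher number more inhibition of growth at the concentration tested. In this assay compound 1 gives 86%. In this assay compound 2 gives 85.9%. Compound 2 stands lowest of the two numbers, but compound 1 sits within the scatter of it, so the pair shows no ordering. Compound 3 `N/C(=N\NC(=S)N1CCSCC1)c1ccc(F)cn1` remains to be measured; it differs from compound 2 by thiomorpholin-4-yl in place of morpholin-4-yl on a thiocarbonyl carbon. Among the measured compounds shown here, no step between measured compounds is available for this change, and in this assay the expected step is none beyond the scatter, a number 0.1 percentage points higher from compound 2 to compound 3 (within the scatter). Compound 3 is accordingly estimated at 86%, ranging from 76% to 94%.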

Compound 3, percent growth inhibition at one concentration: 78.7%
Estimate against measurement, compound 3: 7.3 percentage points above; measured number inside the range.
By their numbers in this assay, from the lowest: compounds 3, 2 and 1 (each within the scatter of the next).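

In this assay thiomorpholin-4-yl in place of morpholin-4-yl on a thiocarbonyl carbon gives a number 7.2 percentage points lower from compound 2 to compound 3 (within the scatter) and is thus not resolved from no change at this position. Fluoro in place of hydrogen on an aromatic carbon gives a number 7.3 percentage points lower from compound 1 to compound 3 (within the scatter) and is likewise unresolved with thiomorpholin-4-yl on the thiocarbonyl carbon. Nothing available bears on a cause for either step. Open, going by these compounds, is whether piperazin-1-yl or a dimethylamino group on the thiocarbonyl carbon would give a step beyond the scatter. Chloro or methoxy in place of fluoro also remains open.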